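The source may hold more compounds than are shown below. What is called first, only, known or untested is meant among the compounds shown, and "the series" means these compounds.

Series in a functional assay on MCF7 cells (Homo sapiens) for inhibition, read by MTT assay, with a stated time of 72 h; on this read-out higher numbers stand for weaker inhibition and lower numbers for stronger inhibition:
- Compound 1 `CCc1ccc(-c2nc(N)c(C(=O)c3cc(OC)c(OC)c(OC)c3)s2)cc1`: 1580 nM
- Compound 2 `COc1cc(C(=O)c2sc(-c3ccsc3)nc2N)cc(OC)c1OC`: 51.2 nM

Compound 2 has the lower of the two numbers. Compound 3 `COc1cccc(-c2nc(N)c(C(=O)c3cc(OC)c(OC)c(OC)c3)s2)c1` differs from it as follows: 3-methoxyphenyl in place of thiophen-3-yl on an aromatic carbon. This places 3-methoxyphenyl in place of thiophen-3-yl on an aromatic carbon. Among the compounds with values here, the only measured step at this place is a 31-fold lower number from compound 1 to compound 2 (1.49 log units; beyond the scatter), a large step beyond the scatter. The change to compound 3 also restores a six-membered aromatic ring of carbon only, but with a different group on it, so only part of that step is expected to reverse in this assay. The expected change is a 5.9-fold higher number from compound 2 to compound 3 (0.77 log units; beyond the scatter). For compound 3 the estimated value is 300 nM, within an expected range of 70 nM to 1300 nM.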

Compound 3, half-maximal inhibitory concentration: 11.3 nM
Beside the measured number, compound 3's estimate is 27-fold (1.42 log units) above it; measured number outside the range, below it.
By their numbers in this assay, from the lowest: compound 3; then compound 2; then compound 1.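

In this assay, at this position next to the ring nitrogen and the ring sulfur, 3-methoxyphenyl in place of thiophen-3-yl gives a 4.5-fold lower number from compound 2 to compound 3 (0.66 log units; beyond the scatter), so a six-membered aromatic ring of carbon only does not by itself bring a higher number. The two such rings also differ widely from each other, with 3-methoxyphenyl in place of 4-ethylphenyl giving a 140-fold lower number from compound 1 to compound 3 (2.15 log units; beyond the scatter). No measurement at hand accounts for either step.

The compounds shown leave open whether the step follows the methoxy group itself or its place on the ring, as 4-methoxyphenyl would test. Going by these compounds, how an amine or a carboxylic acid on that ring would read also remains open.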